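A few compounds are considered here, and "the series" means these few. Any claim that something is new, unique, unknown or untested is made for them only; others in the source may bear on it.

Measured so far:
compound 1 `CCCCCCCCCCc1ccc(-c2noc([C@@H]3CCNC3)n2)cc1` — in an assay on HeLa cells for inhibition of sphingosine-1-phosphate transporter SPNS2 (Mus musculus), read by LC-MS, tested at 2 uM (on this read-out higher numbers stand for more inhibition at the one concentration tested (going by the name of the read-out) and lower numbers for less inhibition), compound 1 gives 62%
compound 2 `CCCCCCCCCCc1ccc(-c2noc([C@@H]3CCC[C@@H](N)C3)n2)cc1` — in this assay compound 2 gives 13%

Among the compounds with values here, compound 2 stands lowest of the two numbers in this assay; the one step recorded is a number 49 percentage points lower from compound 1 to compound 2 (beyond the scatter), a large fall. Compound 3 `CCCCCCCCCCc1ccc(-c2noc([C@@H](N)CCCCN)n2)cc1` differs from compound 2 by 1,5-diaminopentyl in place of 3-aminocyclohexyl on an aromatic carbon. Within the data shown here, no measured step covers a ring-to-chain change of this kind, so the sign of the step is not fixed by the data; the single large step from compound 1 to compound 2 shows only that this position moves the read-out strongly. A moderate change in either direction is expected, a number 17 percentage points higher from compound 2 to compound 3 (beyond the scatter). Compound 3 is estimated at 30%, within 5% to 60%.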

Compound 3, a percentage reported as inhibition, at one concentration (the size of the read-out at that concentration, not a potency): 43%
Estimate against measurement, compound 3: 13 percentage points below; low and high end bracket the measured number.
By their numbers in this assay, from the lowest: compound 2; then compound 3; then compound 1.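

In this assay, replacing 3-aminocyclohexyl with the open 1,5-diaminopentyl gives a number 30 percentage points higher from compound 2 to compound 3 (beyond the scatter), so a ring is not required at this position for a number well above that of compound 2. Against pyrrolidin-3-yl, the same chain gives a number 19 percentage points lower from compound 1 to compound 3 (beyond the scatter), leaving compound 1 highest of the three. Nothing available explains either step.

Compound 3 differs from compound 2 in both ring and amine count, and these two changes stay unseparated. A piperidin-3-yl ring or a pentyl chain carrying a single amine would address that.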